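A few compounds are considered here, and "the series" means these few. Any claim that something is new, unique, unknown or untested is made for them only; others in the source may bear on it.

Compound 1 `CCC(C)n1ncn(-c2ccc(N3CCN(c4ccc(OC[C@@H]5CO[C@@](CC)(c6ccc(Cl)cc6Cl)O5)cc4)CC3)cc2)c1=O` gives 353 nM
Compound 2 `CCC(C)n1ncn(-c2ccc(N3CCN(c4ccc(OC[C@@H]5CO[C@@](Cn6cnc(C(F)(F)F)n6)(c6ccc(Cl)cc6Cl)O5)cc4)CC3)cc2)c1=O` gives 270 nM

In a functional assay on HUVEC cells (Homo sapiens), read by scintillation counting and thymidine incorporation, with a stated time of 24 h (a lower number here means a stronger inhibitor, a higher number a weaker inhibitor), compound 2 gives 270 nM and stands within the scatter of compound 1. Compound 3 `CCC(C)n1ncn(-c2ccc(N3CCN(c4ccc(OC[C@@H]5CO[C@@](Cn6ccnc6C(C)C)(c6ccc(Cl)cc6Cl)O5)cc4)CC3)cc2)c1=O` carries 2-isopropyl-1H-imidazol-1-yl in place of 3-(trifluoromethyl)-1H-1,2,4-triazol-1-yl on a saturated chain carbon bound to a saturated ring carbon. Within the data shown here, the one measured step at this place, 3-(trifluoromethyl)-1H-1,2,4-triazol-1-yl in place of methyl (a 1.3-fold lower number from compound 1 to compound 2 (0.12 log units; within the scatter)), stayed within the scatter, so no step beyond the scatter is expected in this assay here. The expected change (a 1.1-fold higher number from compound 2 to compound 3 (0.05 log units; within the scatter)) is correspondingly small. The expected value for compound 3 is 300 nM (estimated range 120 nM to 750 nM).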

Compound 3, half-maximal inhibitory concentration: 84 nM
Estimate against measurement, compound 3: 3.6-fold (0.55 log units) above, and the stated range ends above it.
By their numbers in this assay, from the lowest: compound 3; then compounds 2 and 1 (each within the scatter of the next).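

In this assay the group on a saturated chain carbon bound to a saturated ring carbon now clearly matters: 2-isopropyl-1H-imidazol-1-yl in place of 3-(trifluoromethyl)-1H-1,2,4-triazol-1-yl gives a 3.2-fold lower number from compound 2 to compound 3 (0.51 log units; beyond the scatter) and in place of methyl gives a 4.2-fold lower number from compound 1 to compound 3 (0.62 log units; beyond the scatter). Both steps lie beyond the scatter, which the earlier step did not. Nothing measured here accounts for the difference. On these data alone, it remains open whether the imidazole ring or its isopropyl group carries the gain, and how a plain 1H-imidazol-1-yl or an open-chain amine would compare at this place.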